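A few compounds are considered here, and "the series" means these few. Any claim that something is new, unique, unknown or untested is made for them only; others in the source may bear on it.

Measured in an assay on isolated protein for inhibition of cytosolic endo-beta-N-acetylglucosaminidase (Homo sapiens), tested at 1000 uM; on this read-out higher numbers stand for more inhibition at the one concentration tested (going by the name of the read-out) and lower numbers for less inhibition:
compound 1 `O=C(O)[C@@H]1NCC=C[C@@H]1O` gives 14%
compound 2 `O=C(O)[C@H]1NC[C@H](O)[C@H](O)[C@H]1O` gives 7.6%
compound 3 `O=C(O)[C@@H]1NCC=C[C@H]1O` gives 14%

Compound 3 stands level with compound 1 at the digits reported, the two together the highest of the three numbers in this assay; compound 2 reads lower, but the gap stays within the scatter, so no order among the three is claimed.

Compound 4 `O=C(O)[C@H]1NCC=C[C@@H]1O` is the next member for this assay. Its relation to compound 3: the two compounds have the same atoms and bonds and differ only in configuration as drawn: 2 of 2 stereo elements differ (all stereocentres are inverted: mirror images); a stereocentre at a saturated ring carbon is drawn R in compound 3 and S in compound 4; a stereocentre at a saturated ring carbon is drawn R in compound 3 and S in compound 4.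

Among the compounds with values here, the only measured step that bears on a change of configuration alone is no change at the digits printed from compound 1 to compound 3 (within the scatter); the evidence behind it is the fact that compounds 1 and 3 differ only in the configuration as drawn. Inverting a single saturated ring stereocentre there left the number unchanged within the scatter. Within the data shown here, the move to compound 4 inverts both stereocentres, giving the mirror image; no measured pair shows how a mirror image behaves, so the epimer step is the only guide, and all three measured values sit within the scatter of one another.

Compound 4 is therefore expected to give 13%, with a range from 4% to 22%. The expected step of a number 1 percentage points lower from compound 3 to compound 4 (within the scatter) is no change beyond the scatter.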

Compound 4, a percentage reported as inhibition, at one concentration (the size of the read-out at that concentration, not a potency): 60%
Estimate against measurement, compound 4: 47 percentage points below; measured number above the stated range.
By their numbers in this assay, from the lowest: compounds 2, 1 and 3 (each within the scatter of the next); then compound 4.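

In this assay, configuration alone now decides the outcome, which the earlier epimer pair did not show: inverting one saturated ring stereocentre gives a number 46 percentage points higher from compound 1 to compound 4 (beyond the scatter), whereas inverting the other gave no change at the digits printed from compound 1 to compound 3 (within the scatter), so the two stereocentres are not interchangeable in this series. Inverting both stereocentres gives a number 46 percentage points higher from compound 3 to compound 4 (beyond the scatter), so the mirror images are clearly separated and the series shows a preference for one hand. The difference cannot be assigned to any change of group, because atoms and bonds stay the same: the fact that compounds 1 and 4 differ only in the configuration as drawn

On these data alone, whether the number of compound 4 holds when the carboxylic acid gives way to an amide or a hydroxymethyl group, or the hydroxyl to a methoxy group, stays open. The read-out at one concentration also leaves the potency of compound 4 open.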